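The source may hold more compounds than are shown below. What is called first, only, known or untested is meant among the compounds shown, and "the series" means these compounds.

Measured compounds in a functional assay on PC-3 cells (Homo sapiens) for cytotoxicity, read by MTT assay, with a stated time of 72 h; a higher number here means a weaker inhibitor, a lower number a stronger inhibitor:
compound 1 `CC1=C(/C=C/C(=O)/C=C/c2cc(C(F)(F)F)cc(C(F)(F)F)c2)C(C)(C)CCC1O` — 7000 nM
compound 2 `CC1=C(/C=C/C(=O)/C=C/c2cccc(F)c2)C(C)(C)CCC1O` — 16000 nM

Compound 2 gives the highest of the two numbers; the nearest is compound 1, whose value is lower by a gap that falls beyond the usual scatter of this kind of measurement. Compound 3 `CC1=C(/C=C/C(=O)/C=C/c2cc(F)cc(C(F)(F)F)c2)C(C)(C)CCC1O` has not yet been tested in this assay. It differs from compound 2 in one place: trifluoromethyl in place of hydrogen on an aromatic carbon. The new group sits on an aromatic carbon of a six-membered aromatic ring of carbon only, meta to a fluoro group and meta to a large group, so that compound 3 carries one trifluoromethyl where compound 1 carries two and compound 2 carries none. On the strength of the two numbers in hand, compound 3 is expected to land between them, and the step from compound 2 to compound 3 is expected to be a modest move toward a lower number, a 1.7-fold lower number from compound 2 to compound 3 (0.23 log units; within the scatter). For compound 3 the estimated value in this assay is 9500 nM, with a range from 4500 nM to 20000 nM.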

Compound 3, half-maximal inhibitory concentration: 3000 nM
Estimate against measurement, compound 3: 3.2-fold (0.50 log units) above; the whole stated range lies above it.
By their numbers in this assay, from the lowest: compound 3; then compound 1; then compound 2.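

In this assay, trifluoromethyl in place of hydrogen on this aromatic carbon gives a 5.3-fold lower number from compound 2 to compound 3 (0.73 log units; beyond the scatter), so this place, meta to a fluoro group, accepts the larger group with a gain beyond the scatter. The reverse comparison, fluoro in place of trifluoromethyl on an aromatic carbon, gives a 2.3-fold lower number from compound 1 to compound 3 (0.37 log units; beyond the scatter), which shows that the number does not simply fall as trifluoromethyl groups accumulate, since compound 1, with two, stands above compound 3, with one. Nothing measured here accounts for either step. The compounds shown leave open whether a nitrile, a methoxy group or a chlorine atom on this carbon would match trifluoromethyl. They also leave open whether the same step would hold with a chlorine atom or a methyl group in place of the fluoro group.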